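Enlarging a branched side chain in a nitrile cathepsin S inhibitor

A few compounds are considered here, and "the series" means these few. Any claim that something is new, unique, unknown or untested is made for them only; others in the source may bear on it.

Compound 1 `CC(C)C[C@H](NC(=O)N1CCOCC1)C(=O)N[C@@H](C)C#N` gives 142 nM in an assay for inhibition of cathepsin S (Homo sapiens); a lower number here means a stronger inhibitor, a higher number a weaker inhibitor.
Compound 2 `CC(C)C[C@H](NC(=O)N1CCOCC1)C(=O)N[C@H](C#N)COCc1cccc(Cl)c1` gives 9 nM in this assay.
Compound 3 `CC(C)[C@H](NC(=O)N1CCOCC1)C(=O)N[C@H](C#N)CCc1ccccc1` gives 6000 nM in this assay.

Compound 3 stands highest of the three numbers, weaker than compound 1 and furthest from compound 2, both gaps beyond the scatter. Compound 4 `CC(C)(C)C[C@H](NC(=O)N1CCOCC1)C(=O)N[C@H](C#N)CCc1ccccc1` differs from compound 3 by one change: neopentyl in place of isopropyl on a saturated chain carbon bound to an amide-type nitrogen and a carbonyl carbon. Among the measured compounds shown here, the only measured step, a 16-fold lower number from compound 1 to compound 2 (1.20 log units; beyond the scatter), concerns a different position and says nothing direct about this change. Compound 1 and compound 3 differ in two places, so their values cannot be split between them. For the measured compounds named here, with no step of this kind measured, a moderate gain is expected for compound 4, a 7.5-fold lower number from compound 3 to compound 4 (0.88 log units; beyond the scatter), with wide uncertainty. Compound 4 is estimated at 800 nM, between 150 nM and 4000 nM.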

Compound 4, half-maximal inhibitory concentration: 23 nM
Compound 4: middle estimate off by 35-fold (1.54 log units), on the high side, and the stated range ends above it.
By their numbers in this assay, from the lowest: compound 2; then compound 4; then compound 1; then compound 3.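

In this assay the side chain on this saturated chain carbon bound to an amide-type nitrogen and a carbonyl carbon matters greatly, since neopentyl in place of isopropyl gives a 260-fold lower number from compound 3 to compound 4 (2.42 log units; beyond the scatter) and so a large step. The swap involves carbon alone, with no ring, hydrogen-bond donor or hydrogen-bond acceptor entering or leaving. Nothing available explains why the step is so large. On these data alone, it remains open whether cyclohexylmethyl or benzyl at this position would lower the number further, and whether the same swap gives a step of this size on the core of compound 2.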